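Losing the Nitrogen Hydrogen: Compound 3 to Compound 4

This account rests on a few compounds, and the source may have more. Where it says the series, first, only, none or still open, it means among the compounds named here.

compound 1 `O=C1OCC=C1CSC(=S)NC1CC1` gives 24100 nM
compound 2 `CN(C)C(=S)SCC1=CCOC1=O` gives 114000 nM
compound 3 `CNC(=S)SCC1=CCOC1=O` gives 36100 nM

In a functional assay on HeLa cells (Homo sapiens) for antiproliferative activity, read by MTT assay, with a stated time of 72 h (a lower number here means a stronger inhibitor, a higher number a weaker inhibitor), compound 3 gives 36100 nM as its reading. That value lies within the scatter of its nearest neighbour, with a 1.5-fold higher number from compound 1 to compound 3 (0.18 log units; within the scatter) as the gap, and the furthest value is set off by a 3.2-fold lower number from compound 2 to compound 3 (0.50 log units; beyond the scatter) on the same scale.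

Compound 4 `O=C1OCC=C1CSC(=S)N1CCCC1` carries pyrrolidin-1-yl in place of methylamino on a thiocarbonyl carbon, and pyrrolidin-1-yl in place of methylamino on a thiocarbonyl carbon counts that change. The hydrogen-bond donor leaves with methylamino, so compound 4 shares with compound 2 a nitrogen without a hydrogen.

Within the data shown here, two measured steps bear on this. Both a 4.7-fold higher number from compound 1 to compound 2 (0.67 log units; beyond the scatter) and a 3.2-fold lower number from compound 2 to compound 3 (0.50 log units; beyond the scatter) are modest, and in both the compound lacking that hydrogen has the higher number. By contrast, a 1.5-fold higher number from compound 1 to compound 3 (0.18 log units; within the scatter) joins two compounds that keep the hydrogen and stays within the scatter. Only compound 2 tests the loss, however, and its dimethylamino has no ring, so the guide is imperfect.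

A modest rise in this assay is therefore expected, somewhat smaller than those steps. The expected step is a 2.2-fold higher number from compound 3 to compound 4 (0.35 log units; beyond the scatter) in this estimate. For compound 4 the estimated value is 80000 nM with an expected range from 30000 nM to 200000 nM in this assay.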

Compound 4, half-maximal inhibitory concentration: 2630 nM
Beside the measured number, compound 4's estimate is 30-fold (1.48 log units) above it, and the stated range ends above it.
By their numbers in this assay, from the lowest: compound 4; then compounds 1 and 3 (each within the scatter of the next); then compound 2.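

Removing the hydrogen from the nitrogen on the thiocarbonyl carbon does not by itself bring a higher number in this assay, since pyrrolidin-1-yl in place of methylamino gives a 14-fold lower number from compound 3 to compound 4 (1.14 log units; beyond the scatter) even though the entering group has no hydrogen-bond donor. Compound 2 also lacks that hydrogen, yet the comparison with its open-chain dimethylamino group gives a 43-fold lower number from compound 2 to compound 4 (1.64 log units; beyond the scatter) and shows that the link seen earlier between losing the hydrogen and a higher number rests on compound 2 alone, with compound 4 going against it. A ring in the amine part is not enough to match compound 4 either, as the cyclopropylamino group of compound 1 still leaves a 9.2-fold lower number from compound 1 to compound 4 (0.96 log units; beyond the scatter) and compound 4 has the lowest number of the four.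

As far as these compounds go, whether this gain is tied to the five-membered ring remains open, and a piperidin-1-yl or morpholin-4-yl group on the same thiocarbonyl carbon would test that directly. Nothing available here explains why pyrrolidin-1-yl gives so much lower a number than the other groups.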